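The compounds below may be only part of what the source reports. "The series", "measured", "known", "first", "only" and "open" are said of these compounds alone.

Of the compounds shown here, three built on a shared core have been measured in a functional assay on MCF7 cells (Homo sapiens) for inhibition, read by MTT assay, with a stated time of 48 h; a lower number here means a stronger inhibitor, a higher number a weaker inhibitor. Compound 1 `O=C(Nc1cnn(-c2ccccc2)c1)c1cccc(NS(=O)(=O)c2ccccc2)c1` gives 4320 nM in this assay. Compound 2 `Cc1ccc(-n2cc(NC(=O)c3cccc(NS(=O)(=O)c4ccc(Cl)cc4)c3)cn2)cc1` gives 1080 nM in this assay. Compound 3 `Cc1ccc(-n2cc(NC(=O)c3ccc(NS(=O)(=O)c4ccccc4)cc3)cn2)cc1` gives 10900 nM in this assay, the highest of the three numbers, so among these three it is the weakest inhibitor; its gap to compound 1 is the smaller one and its gap to compound 2 the larger one, and both gaps lie beyond the usual scatter.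

Compound 4 `COc1cccc(-n2cc(NC(=O)c3ccc(NS(=O)(=O)c4ccccc4)cc3)cn2)c1` differs from compound 3 in a single place: 3-methoxyphenyl in place of 4-methylphenyl on an aromatic nitrogen. In words, this is 3-methoxyphenyl in place of 4-methylphenyl on an aromatic nitrogen. Within the data shown here, no measured pair among compounds 1, 2 and 3 isolates this exchange, since those three differ from one another in more than one part of the molecule at once. With nothing to rest on beyond the value of compound 3, a step no larger than the scatter is expected, in no particular direction. Compound 4 is therefore estimated at 9000 nM in this assay, within a range from 3000 nM to 27000 nM. This estimate means a step of a 1.2-fold lower number from compound 3 to compound 4 (0.08 log units; within the scatter), expected to stay within the scatter.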

Compound 4, half-maximal inhibitory concentration: 28400 nM
Estimate against measurement, compound 4: 3.2-fold (0.50 log units) below; measured number outside the range, above it.
By their numbers in this assay, from the lowest: compound 2; then compound 1; then compound 3; then compound 4.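

In this assay, among these compounds, the group on the aromatic nitrogen proves able to move the number: 3-methoxyphenyl in place of 4-methylphenyl gives a 2.6-fold higher number from compound 3 to compound 4 (0.42 log units; beyond the scatter) and so a weaker inhibitor, which is the first reading of this position with everything else held constant. The step is modest, but it shows that this exchange is not neutral here, something compounds 1, 2 and 3 could not show because they differ from one another in more than one place. The exchange alters two things at once, since the entering group brings an oxygen and a hydrogen-bond acceptor and also carries its substituent at a different place on the phenyl ring, and nothing available accounts for the loss.

Still open, as far as these compounds go, is whether methyl and methoxy would rank the same way if each sat at the same place on that phenyl ring, which would separate the identity of the group from its location. Also open, from the compounds shown here alone, is how an amine or a carboxylic acid on this ring would compare with the methyl and methoxy groups.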